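Swapping chloro for methoxy on a pyrazoline-bearing pyrimidinone series

The compounds below may be only part of what the source reports. "The series", "measured", "known", "first", "only" and "open" are said of these compounds alone.

Of the compounds shown here, three of one family have been tested in a functional assay on MDA-MB-231 cells (Homo sapiens) for antiproliferative activity, with a stated time of 72 h; a higher number here means a weaker inhibitor, a lower number a stronger inhibitor. Compound 1 `Cn1c(N2N=C(c3ccccc3)CC2c2ccc(Cl)cc2)nc(-c2ccc(Cl)cc2)c(C#N)c1=O` gives 25100 nM. Compound 2 `COc1ccc(C2CC(c3ccccc3)=NN2c2nc(-c3ccc(Cl)cc3)c(C#N)c(=O)n2C)cc1` gives 19500 nM, and compound 3 `COc1ccc(C2CC(c3ccc(Cl)cc3)=NN2c2nc(-c3ccc(Cl)cc3)c(C#N)c(=O)n2C)cc1` gives 24800 nM. The change from compound 1 to compound 2 is methoxy in place of chloro on an aromatic carbon, and it made a step of a 1.3-fold lower number from compound 1 to compound 2 (0.11 log units; within the scatter). From compound 2 to compound 3 the step was a 1.3-fold higher number from compound 2 to compound 3 (0.10 log units; within the scatter).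

Compound 4 `COc1ccc(C2=NN(c3nc(-c4ccc(Cl)cc4)c(C#N)c(=O)n3C)C(c3ccc(OC)cc3)C2)cc1` has not yet been measured. For the measured compounds named here, it differs from compound 3 by methoxy in place of chloro on an aromatic carbon, which is the same change as the one from compound 1 to compound 2; the difference between the two cores, compound 1 against compound 3, is not broken down here. Since the earlier step of this change stayed within the scatter, as seen in a 1.3-fold lower number from compound 1 to compound 2 (0.11 log units; within the scatter), a step of similar size is expected from compound 3 to compound 4, namely a 1.2-fold lower number from compound 3 to compound 4 (0.09 log units; within the scatter). On that basis compound 4 is estimated at 20000 nM, with a likely range from 10000 nM to 40000 nM, to be set against the value that the measurement will give.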

Compound 4, half-maximal inhibitory concentration: 28300 nM
For compound 4 the middle estimate is 1.4-fold (0.15 log units) below the measured one, and the stated range covers the measured number.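

The swap of 4-chlorophenyl to 4-methoxyphenyl in this assay gives a 1.1-fold higher number from compound 3 to compound 4 (0.06 log units; within the scatter), and the other new comparison gives a 1.5-fold higher number from compound 2 to compound 4 (0.16 log units; within the scatter), so neither pair of compounds can be told apart in this test. Set beside the earlier case, the same swap on the other core gives a result that cannot be told apart from this one: the same change on two cores in this assay, a 1.3-fold lower number (0.11 log units; within the scatter) from compound 1 to compound 2 and a 1.1-fold higher number (0.06 log units; within the scatter) from compound 3 to compound 4, 1.5-fold (0.17 log units) apart, within the scatter of two such steps This shows that, on these two cores, the swap carries over without any readable effect, but it does not show that the swap is without effect in general, since a small real effect could hide inside the scatter and two cores are only two cases.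

The compounds shown carry only chloro, methoxy or hydrogen at these places on the aromatic rings. As far as these compounds go, it stays open whether an amine, a carboxylic acid or a longer chain such as butoxy at the same place would give a step beyond the scatter.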